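Swapping the Pyridyl Arm on a Fluorophenyl Tetrazole Core

This account rests on a few compounds, and the source may have more. Where it says the series, first, only, none or still open, it means among the compounds named here.

Compound 1: `Cc1cnccc1-c1cc(F)cc(-n2nnc(-c3ccccn3)n2)c1` — 33 nM
Compound 2: `Cc1ccncc1-c1cc(F)cc(-n2nnc(-c3ccccn3)n2)c1` — 2 nM

Both compounds were tested in an assay for binding affinity to metabotropic glutamate receptor 5 (Rattus norvegicus); on this read-out higher numbers stand for weaker inhibition and lower numbers for stronger inhibition. Compound 1 carries the higher of the two numbers; its nearest neighbour is compound 2, and the step of a 17-fold lower number from compound 1 to compound 2 (1.22 log units; beyond the scatter) shows how strongly a rearranged methylpyridyl arm can move this read-out.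

Compound 3 (`Nc1cccnc1-c1cc(F)cc(-n2nnc(-c3ccccn3)n2)c1`) has not yet been measured in this assay. It differs from compound 1 in one place: 3-aminopyridin-2-yl in place of 3-methylpyridin-4-yl on an aromatic carbon. Going by the values given here, no measured step involves an aminopyridyl group, so the only guide is that a changed pyridyl arm, from compound 1 to compound 2, shifted the number well beyond the scatter. Among the compounds with values here, with no direct precedent, the expectation is a number close to that of compound 1, a 1.1-fold lower number from compound 1 to compound 3 (0.04 log units; within the scatter), but with a wide range. Compound 3 is therefore estimated at 30 nM, between 5 nM and 200 nM.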

Compound 3, inhibition constant: 31 nM
Compound 3: the middle estimate sits 1.0-fold (0.01 log units) below what was measured; low and high end bracket the measured number.
By their numbers in this assay, from the lowest: compound 2; then compounds 3 and 1 (each within the scatter of the next).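

In this assay, the step is a 1.1-fold lower number from compound 1 to compound 3 (0.03 log units; within the scatter), so 3-aminopyridin-2-yl, which carries a hydrogen-bond donor that 3-methylpyridin-4-yl lacks, gives a number within the scatter of that arm. The step of a 16-fold higher number from compound 2 to compound 3 (1.19 log units; beyond the scatter) shows that changing this arm does not by itself bring the number to the level of compound 2: of these three compounds, only compound 2, with its 4-methylpyridin-3-yl arm, stands apart from both others beyond the scatter. No supporting data are available to explain why these arms compare as they do.

The arms of compound 1 and compound 3 differ in both their substituent and their ring arrangement, so the contribution of each remains unresolved. On these data alone, how a methoxy group, an unsubstituted pyridyl arm or a plain phenyl ring would fare at this position also remains open.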